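A few compounds are considered here, and "the series" means these few. Any claim that something is new, unique, unknown or untested is made for them only; others in the source may bear on it.

Working notes on the series, read in an ADME assay on microsomes from liver (Rattus norvegicus) for metabolic stability, read by LC-MS, using NADPH, with a stated time of 10 min, tested at 0.5 uM; a higher number here means that more of the compound is left, a lower number that less of the compound is left. Compound 1 (`COC(=O)Nc1cc(-c2ccc(OC[C@@](C)(N)CC(C)C)c(C)c2)ccn1`) gives 96%, and compound 2 (`COC(=O)Nc1cc(-c2ccc(OC[C@@](C)(N)CC(C)C)cn2)ccn1`) gives 100%. These two values lie within the scatter of each other, so compound 2 stands level with compound 1, and both sit near the top of the scale.

Compound 3 (`COC(=O)Nc1cc(-c2ccc(OC[C@@](C)(N)CC(C)C)c(Cl)n2)ccn1`) departs from compound 2 in one place: chloro in place of hydrogen on an aromatic carbon, next to the ring nitrogen and ortho to the (2-amino-2,4-dimethylpentyl)oxy group (chloro in place of hydrogen on an aromatic carbon). Among the compounds with values here, no measured step shows what such a change does, so the expectation rests only on compound 2 at 100%. A small downward move or none beyond the scatter is expected in this assay. The expected step is a number 7 percentage points lower from compound 2 to compound 3 (within the scatter). For compound 3 the estimated value is 93%, with an expected range of 78% to 100%.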

Compound 3, percent of the compound remaining: 99%
Beside the measured number, compound 3's estimate is 6 percentage points below it; low and high end bracket the measured number.
By their numbers in this assay, from the lowest: compounds 1, 3 and 2 (each within the scatter of the next).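

In this assay, chloro in place of hydrogen on an aromatic carbon, next to the ring nitrogen and ortho to the (2-amino-2,4-dimethylpentyl)oxy group, gives a number 1 percentage points lower from compound 2 to compound 3 (within the scatter). Within the data shown here, this is the first one-place step, and it shows that at this position the percent of compound remaining does not separate compound 3 from compound 2. Nothing at hand explains this result.

Open, on these data alone, is whether a methoxy group, a trifluoromethyl group or an amine at this same position would also stay within the scatter of compound 2. As far as these compounds go, with compound 2 and compound 3 both near the top of the scale, it also remains open whether chloro here would matter in a compound with less left at the end of the incubation.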